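This account rests on a few compounds, and the source may have more. Where it says the series, first, only, none or still open, it means among the compounds named here.

In an ADME assay on MDCK cells (Canis lupus familiaris) for cytotoxicity, read by MTT assay, with a stated time of 48 h (a lower number here means that less compound is tolerated, a higher number that more compound is tolerated), compound 2 `FC(F)(F)c1ccccc1-c1cn(CC2=C(Cl)c3ccc(-c4cccs4)nc3CC2)nn1` gives > 300 ug/mL. This is a limit of the assay and not a number, so its true distance from compound 3 cannot be fixed: the limit of > 300 ug/mL in this assay, at which 1 of the 2 values shown sits. Compound 1 `O=[N+]([O-])c1ccc(-c2cn(CC3=C(Cl)c4ccc(-c5cccs5)nc4CC3)nn2)cc1` gives a measured 40 ug/mL in this assay.

Compound 3 `ClC1=C(Cn2cc(-c3ccsc3)nn2)CCc2nc(-c3cccs3)ccc21` keeps the shared core and carries thiophen-3-yl in place of 2-(trifluoromethyl)phenyl on an aromatic carbon of the five-membered aromatic ring with 3 nitrogen: thiophen-3-yl in place of 2-(trifluoromethyl)phenyl on an aromatic carbon.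

For the measured compounds named here, only one measured step bears on this change. The step of an at least 7.5-fold higher number from compound 1 to compound 2 (0.87 log units; beyond the scatter) swaps the group at the same place and lies beyond the scatter, so this group can shift the reading. Going by the values given here, no measured compound carries thiophen-3-yl, so that step gives only a rough size and no firm direction. Compound 2 stands at the limit with > 300 ug/mL, which leaves room for movement mainly towards lower numbers.

A modest fall is expected, with the estimated change being an at least 2.0-fold lower number from compound 2 to compound 3 (0.30 log units; that floor lies within the scatter). The expected value for compound 3 is 150 ug/mL, with an estimated range of 45 ug/mL to 300 ug/mL.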

Compound 3, half-maximal cytotoxic concentration: > 300 ug/mL
Compound 3: only a limit was reported; the forecaster's own chance of this, stated with the estimate: 35%; middle value at least 2.0-fold (0.30 log units) away from the limit.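

In this assay compound 3 gives > 300 ug/mL, which is a limit of the assay and not a number. The reading on the aromatic carbon of the five-membered aromatic ring with 3 nitrogen now has a second replacement for 4-nitrophenyl behind it, an at least 7.5-fold higher number from compound 1 to compound 3 (0.87 log units; beyond the scatter), so compound 1 goes against both other compounds, and two different groups, thiophen-3-yl with its five-membered aromatic ring with 1 hetero atom and 2-(trifluoromethyl)phenyl with its six-membered aromatic ring of carbon only, leave the shared core at the same limit. The step between compound 2 and compound 3 cannot be read, because both readings are limits: the limit of > 300 ug/mL in this assay, at which 2 of the 3 values shown sit.

On these data alone, the order of compound 2 and compound 3 and their true distance from compound 1 stay open, as does whether the lower number of compound 1 goes with the nitro group or with the 4-nitrophenyl group as a whole. Also open, as far as these compounds go, is how an amine or a carboxylic acid at this place would read in this assay.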